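This account rests on a few compounds, and the source may have more. Where it says the series, first, only, none or still open, it means among the compounds named here.

Values in a functional assay on cells (Cancer cell lines, Homo sapiens) for inhibition; a lower number here means a stronger inhibitor of growth, a higher number a weaker inhibitor of growth:
- compound 1 `Cc1cc(-c2nc3sc(C)cn3c2/C=N/NC(=N)N)c(C)s1`: 13500 nM
- compound 2 `N=C(N)N/N=C/c1c(-c2ccsc2)nc2sccn12`: 31600 nM
- compound 3 `N=C(N)N/N=C/c1c(-c2cccs2)nc2sccn12`: 28200 nM

Compound 3, at 28200 nM, sits with compound 2 at the high end of the three numbers, and compound 1 lies lower, beyond the scatter. Next is compound 4 `Cc1cc(-c2nc3sccn3c2/C=N/NC(=N)N)c(C)s1`, with 2,5-dimethylthiophen-3-yl in place of thiophen-2-yl on an aromatic carbon. Among the compounds with values here, the only measured step, a 1.1-fold lower number from compound 2 to compound 3 (0.05 log units; within the scatter), swaps thiophene attachment and says nothing about the methyl groups. The closest guide is compound 1, which carries the same 2,5-dimethylthiophen-3-yl and gives 13500 nM. A modest lowering in this assay is therefore expected, a 1.6-fold lower number from compound 3 to compound 4 (0.19 log units; within the scatter), near the edge of the scatter. For compound 4 the estimated value is 18000 nM, with an expected range of 10000 nM to 30000 nM.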

Compound 4, concentration for total growth inhibition: 30200 nM
Beside the measured number, compound 4's estimate is 1.7-fold (0.22 log units) below it; measured number outside the range, above it.
By their numbers in this assay, from the lowest: compound 1; then compounds 3, 4 and 2 (each within the scatter of the next).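

In this assay, adding the two methyl groups of 2,5-dimethylthiophen-3-yl changes little at this aromatic carbon: the steps are a 1.1-fold higher number from compound 3 to compound 4 (0.03 log units; within the scatter) and a 1.0-fold lower number from compound 2 to compound 4 (0.02 log units; within the scatter). The methyl on the core of compound 1 is what separates the pair, with a 2.2-fold higher number from compound 1 to compound 4 (0.35 log units; beyond the scatter) when hydrogen replaces it. No available data explain this result.

On these data alone, whether the same methyl on the core gives a similar step with thiophen-2-yl or thiophen-3-yl stays open. So does whether a phenyl ring or an amine at this aromatic carbon would shift the number beyond the scatter.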